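From Ethyl to Propyl: One More Chain Carbon

The compounds below may be only part of what the source reports. "The series", "measured", "known", "first", "only" and "open" are said of these compounds alone.

- Compound 1 `c1cnc2c(c1)CCC[C@@H]2N(CC1CC1)C[C@H]1Cc2c(cccc2N2CCNCC2)CN1` gives 88.3%
- Compound 2 `CN(C[C@@H]1Cc2c(cccc2N2CCNCC2)CN1)[C@H]1CCCc2cccnc21` gives 54.6%
- Compound 3 `CCN(C[C@H]1Cc2c(cccc2N2CCNCC2)CN1)[C@H]1CCCc2cccnc21` gives 53.8%

These values come from an ADME assay on microsomes from liver (Mus musculus) for metabolic stability, read by LC-MS, with a stated time of 10 min; on this read-out lower numbers stand for a less stable compound and higher numbers for a more stable compound. Compound 3 has the lowest of the three numbers, but it lies within the scatter of compound 2 and beyond the scatter of compound 1.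

Compound 4 `CCCN(C[C@H]1Cc2c(cccc2N2CCNCC2)CN1)[C@H]1CCCc2cccnc21` is the next case, and its change reads (methyl in place of hydrogen on a saturated chain carbon, two bonds along the chain from an amine nitrogen). In words, this turns ethyl into propyl.

Among the compounds with values here, one measured step bears on this: a number 34.5 percentage points lower from compound 1 to compound 3 (beyond the scatter), a large step with methyl in place of cyclopropyl on a saturated chain carbon bound to an amine nitrogen. The change in compound 4 is a smaller one at that same carbon, so a modest rise is expected in this assay, and no change beyond the scatter remains possible. The expected step is a number 8.2 percentage points higher from compound 3 to compound 4 (within the scatter). Compound 4 is estimated at 62%, with an expected range from 45% to 80%.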

Compound 4, percent of the compound remaining: 87.4%
Compound 4: middle estimate off by 25.4 percentage points, on the low side, and the stated range ends below it.
By their numbers in this assay, from the lowest: compounds 3 and 2 (each within the scatter of the next); then compounds 4 and 1 (each within the scatter of the next).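

The earlier step at this place pointed only to a loss on going from cyclopropyl to the shorter chain, which left open whether the ring itself mattered. In this assay a single added methyl, turning ethyl into propyl, produces a large step (a number 33.6 percentage points higher from compound 3 to compound 4 (beyond the scatter)), so a sharp difference here does not depend on a ring. The open-chain propyl also matches the cyclopropyl compound within the scatter (a number 0.9 percentage points lower from compound 1 to compound 4 (within the scatter)), and nothing shown here offers an explanation for the size of the jump.

The compounds shown leave open whether the number in this assay stays high with a longer chain such as butyl. They also leave open how a branched group such as isopropyl would behave in this place.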